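The source may report more compounds than this note shows. Statements on the series, on what has been measured and on what is new or still open speak of the compounds shown alone.

Working notes on the series.

In a functional assay on cells for positive allosteric modulation of G-protein coupled receptor 68 (Homo sapiens), read by a luciferase reporter and cAMP accumulation, with a stated time of 30 min, at pH 6.8 and pH 8.3, in the presence of a further agent that is not named here (on this read-out lower numbers stand for lower potency and higher numbers for higher potency (the scale is a negative logarithm)), compound 1 `Nc1nc(NCc2ccc(F)cc2)nc(-c2ccccc2CO)n1` gives 3.97 and stands lowest of the three numbers recorded so far. Compound 2 `CC(C)Oc1ccc(CNc2nc(N)nc(-c3ccccc3CO)n2)cc1` gives 4.99 and compound 3 `Nc1nc(NCc2ccc(OC3CC3)cc2)nc(-c2ccccc2CO)n1` gives 5.07; the step of a number 1.02 log units higher from compound 1 to compound 2 (beyond the scatter) and the step of a number 1.10 log units higher from compound 1 to compound 3 (beyond the scatter) are both large, while the step of a number 0.08 log units higher from compound 2 to compound 3 (within the scatter) is within the scatter.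

Compound 4 `Nc1nc(NCCCc2ccccc2)nc(-c2ccccc2CO)n1` has not been measured in this assay. It differs from compound 1 as follows: phenethyl in place of 4-fluorophenyl on a saturated chain carbon bound to a nitrogen on an aromatic ring. Both known steps from compound 1 replace the fluoro with an alkoxy group on the same aromatic carbon and leave the saturated chain carbon bound to the ring nitrogen untouched; neither removes the fluoro without adding anything, and neither lengthens that chain. Among the measured compounds shown here, no recorded step therefore bears directly on the change to compound 4, and the size of the step in this assay cannot be read from the series.

With that gap, the expectation for compound 4 is a number close to compound 1, with a wide range: an estimated step of a number 0.33 log units higher from compound 1 to compound 4 (beyond the scatter), giving an expected value of 4.3 with a range from 3.6 to 5.1.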

Compound 4, negative logarithm of the antagonist equilibrium constant: 5.22
Estimate against measurement, compound 4: 0.92 log units below, outside the stated range (above it).
By their numbers in this assay, from the lowest: compound 1; then compounds 2, 3 and 4 (each within the scatter of the next).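

In this assay, the step of a number 1.25 log units higher from compound 1 to compound 4 (beyond the scatter) shows that this position, a saturated chain carbon bound to a nitrogen on an aromatic ring, can carry a large change that places no alkoxy group on the aromatic ring. The earlier steps shown here from compound 1 all exchanged fluoro for an oxygen-linked group, whereas the phenethyl entering in compound 4 contains carbon only and, like the 4-fluorophenyl that leaves, counts no hydrogen-bond acceptors, so a step of this size does not depend on adding an oxygen to this part of the molecule. No measurement bearing on the reason for this step is available.

The change in compound 4 removes the fluoro and lengthens the chain together, so the compounds shown leave open how much of the step belongs to each, a question that an unsubstituted benzyl group on the same nitrogen could separate. Also open, on these data alone, are whether a longer chain such as phenylpropyl would extend the step and whether an isopropoxy or cyclopropyloxy group on the phenethyl ring would add to it.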